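Changing the Amine Substituent of Compound 3

The source may report more compounds than this note shows. Statements on the series, on what has been measured and on what is new or still open speak of the compounds shown alone.

Measured in a functional assay on MCF7 cells (Homo sapiens) for antiproliferative activity; a higher number here means a weaker inhibitor, a lower number a stronger inhibitor:
- compound 1 `CC(C)=CCc1cc(C(=O)Nc2cc3ccc(OCC4CCCNC4)c(C)c3oc2=O)ccc1O`: 790 nM
- compound 2 `CCN(C)CCCOc1ccc2cc(NC(=O)c3ccc(O)c(CC=C(C)C)c3)c(=O)oc2c1C`: 2190 nM
- compound 3 `CC(C)=CCc1cc(C(=O)Nc2cc3ccc(OCCCNCCO)c(C)c3oc2=O)ccc1O`: 1560 nM

Compound 3 lies within the scatter of both other compounds, as the data show a 2.0-fold higher number from compound 1 to compound 3 (0.30 log units; within the scatter) and a 1.4-fold lower number from compound 2 to compound 3 (0.15 log units; within the scatter). Compound 4 `CC(C)=CCc1cc(C(=O)Nc2cc3ccc(OCCCNC(C)(C)c4ccccc4)c(C)c3oc2=O)ccc1O` has 1-methyl-1-phenylethyl in place of 2-hydroxyethyl on an amine nitrogen.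

The closest measured change is at this same amine, where the data show a 1.4-fold lower number from compound 2 to compound 3 (0.15 log units; within the scatter). The largest step among the three compounds is a 2.8-fold higher number from compound 1 to compound 2 (0.44 log units; beyond the scatter), which sets a modest scale for changes in this part of the molecule. Going by the values given here, no measured compound carries a 1-methyl-1-phenylethyl group, so this evidence is indirect and the range stays wide. In this assay, no step beyond the scatter is therefore expected. The expected step is a 1.2-fold lower number from compound 3 to compound 4 (0.08 log units; within the scatter). For compound 4 the estimated value is 1300 nM, with an expected range from 450 nM to 3700 nM.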

Compound 4, half-maximal inhibitory concentration: 1070 nM
For compound 4 the middle estimate is 1.2-fold (0.08 log units) above the measured one; low and high end bracket the measured number.
By their numbers in this assay, from the lowest: compounds 1, 4, 3 and 2 (each within the scatter of the next, the first and the last beyond it).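

In this assay, the amine nitrogen accepts a far larger group with no hydrogen-bond donor or acceptor: 1-methyl-1-phenylethyl, with its nine heavy atoms and six-membered aromatic ring, replaces 2-hydroxyethyl with a step within the scatter (a 1.5-fold lower number from compound 3 to compound 4 (0.16 log units; within the scatter)). Going by these compounds alone, compound 4 also stands beyond the scatter of compound 2 (a 2.0-fold lower number from compound 2 to compound 4 (0.31 log units; beyond the scatter)) yet within the scatter of compound 1 (a 1.4-fold higher number from compound 1 to compound 4 (0.13 log units; within the scatter)), whereas compound 3 was within the scatter of both, so this open-chain amine is the first to separate from compound 2 while remaining level with the piperidin-3-yl compound. Nothing available accounts for these differences.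

The compounds shown leave open whether the aromatic ring or the two methyl groups matter, which a benzyl or a tert-butyl group on the same nitrogen would separate. As far as these compounds go, a carboxylic acid in that place also remains untested here.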